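Removing the Whole Side Chain from Compound 2

The source may report more compounds than this note shows. Statements on the series, on what has been measured and on what is new or still open speak of the compounds shown alone.

Compound 2 `O=C1c2c[n+]([O-])c3ccccc3c2C(=O)c2c1c1ccccc1n2Cc1cn(CC(O)CO)nn1` has the weakest figure of the three measured compounds: in a functional assay on A-375 cells (Homo sapiens) for cytotoxicity, read by MTT assay, with a stated time of 72 h (a lower number here means a stronger inhibitor, a higher number a weaker inhibitor), compound 2 gives 440 nM, while compound 1 `O=C1c2c[n+]([O-])c3ccccc3c2C(=O)c2c1c1ccccc1n2Cc1cn([C@@H]2C[C@H](O)[C@@H](CO)O2)nn1` gives 20 nM and compound 3 `CC1(C)O[C@@H](CO)[C@H](Cn2cc(Cn3c4c(c5ccccc53)C(=O)c3c[n+]([O-])c5ccccc5c3C4=O)nn2)O1` gives 190 nM. The steps of a 22-fold higher number from compound 1 to compound 2 (1.34 log units; beyond the scatter) and a 2.3-fold lower number from compound 2 to compound 3 (0.36 log units; beyond the scatter) show that the group on the aromatic nitrogen strongly shapes the result. Compound 4 `O=C1c2c[n+]([O-])c3ccccc3c2C(=O)c2[nH]c3ccccc3c21` differs from compound 2 by hydrogen in place of (1-(2,3-dihydroxypropyl)-1H-1,2,3-triazol-4-yl)methyl on an aromatic nitrogen. Going by the values given here, no measured step removes the side chain entirely, so the known steps bear only loosely on this change and its direction is uncertain. Compound 4 is therefore expected near 500 nM, within a wide range from 100 nM to 3000 nM. This estimate means an expected step of a 1.1-fold higher number from compound 2 to compound 4 (0.06 log units; within the scatter) that may not exceed the scatter.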

Compound 4, half-maximal inhibitory concentration: 660 nM
Compound 4: the middle estimate sits 1.3-fold (0.12 log units) below what was measured, and the stated range covers the measured number.
By their numbers in this assay, from the lowest: compound 1; then compound 3; then compounds 2 and 4 (each within the scatter of the next).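

Replacing the whole side chain with hydrogen on the aromatic nitrogen gives a 1.5-fold higher number from compound 2 to compound 4 (0.18 log units; within the scatter) in this assay. The earlier steps shown here compared only one side chain with another; this one shows that the (1-(2,3-dihydroxypropyl)-1H-1,2,3-triazol-4-yl)methyl group and a bare hydrogen cannot be told apart at this position. No measurement shown here offers an explanation for this result. Still open, going by these compounds, is how a small methyl group on this nitrogen would read, and whether a chain ending in an amine or a carboxylic acid would differ from hydrogen.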